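Chain Extension Beside the Amide in Rat Cell Cytotoxicity

A few compounds are considered here, and "the series" means these few. Any claim that something is new, unique, unknown or untested is made for them only; others in the source may bear on it.

Measured compounds:
compound 1, `CCN(CC)C(=O)CNC1CC2(N3CCN(C)CC3)CC(c3ccccc3)C1C(c1ccccc1)C2`: 37900 nM
compound 2, `CN1CCN(C23CC(NC(=O)CN4CCCCC4)C(C(c4ccccc4)C2)C(c2ccccc2)C3)CC1`: 22100 nM

In an ADME assay on L6 cells (Rattus norvegicus) for cytotoxicity, read by fluorescence, with a stated time of 72 h (on this read-out higher numbers stand for weaker inhibition and lower numbers for stronger inhibition), compound 1 gives 37900 nM and compound 2 gives 22100 nM. Going by the values given here, compound 2 holds the lower of the two numbers, yet the single measured step, a 1.7-fold lower number from compound 1 to compound 2 (0.23 log units; within the scatter), lies within the scatter, so no order between the two compounds can be read from these figures.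

Compound 3, `CN1CCN(C23CC(NC(=O)CCN4CCCCC4)C(C(c4ccccc4)C2)C(c2ccccc2)C3)CC1`, differs from compound 2 in one place: (piperidin-1-yl)methyl in place of piperidin-1-yl on a saturated chain carbon bound to a carbonyl carbon

Among the compounds with values here, only one measured step exists to lean on, a 1.7-fold lower number from compound 1 to compound 2 (0.23 log units; within the scatter), and it concerns an exchange of one whole amide-side group for another, not a lengthening of the chain by one unit as here. That step stayed within the scatter, and nothing measured points to a shift in either direction for a change of this kind. Compound 3 is therefore expected to give about 22000 nM in this assay, within a range of 8000 nM to 60000 nM. This estimate means a step of a 1.0-fold lower number from compound 2 to compound 3 (0.00 log units; within the scatter), which is expected to stay within the scatter of repeated measurements.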

Compound 3, half-maximal inhibitory concentration: 15400 nM
Compound 3: the middle estimate sits 1.4-fold (0.15 log units) above what was measured; the measured number falls inside the stated range.
By their numbers in this assay, from the lowest: compounds 3, 2 and 1 (each within the scatter of the next, the first and the last beyond it).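

In this assay, the one-unit extension gives a 1.4-fold lower number from compound 2 to compound 3 (0.16 log units; within the scatter), so lengthening the chain at this saturated carbon bound to a carbonyl carbon cannot be told apart from repeat measurement. Going by these compounds alone, the wider exchange, (2-(piperidin-1-yl)ethyl)carbonyl in place of (diethylcarbamoyl)methyl on an amine nitrogen, gives a 2.5-fold lower number from compound 1 to compound 3 (0.39 log units; beyond the scatter), the first step to pass the scatter, although only modestly, and compound 2 lies within the scatter of both compounds and so marks no clear intermediate stage. The data offered here give no explanation for either step.

Going by these compounds, it remains open whether a still longer chain, such as 3-(piperidin-1-yl)propyl, would continue the small drift in the numbers or leave them within the scatter of compound 3. Also unresolved is whether the piperidin-1-yl ring matters at the end of the chain, a question that morpholin-4-yl or an open-chain amine such as diethylamino at the same place would address.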